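The source may hold more compounds than are shown below. What is called first, only, known or untested is meant among the compounds shown, and "the series" means these compounds.

Compound 1 `COc1ccc([C@@H]2CC(=O)c3cc(CC=C(C)C)c(OC)cc3O2)cc1`: 68%
Compound 2 `COc1cc2c(cc1CC=C(C)C)C(=O)C[C@@H](c1ccc(Oc3ccccc3)cc1)O2`: 76%

In a functional assay on HCT-116 cells (Homo sapiens) for inhibition, read by sulforhodamine B assay, with a stated time of 48 h, tested at 50 uM (a higher number here means more inhibition of growth at the concentration tested, a lower number less inhibition of growth), compound 2 gives 76%, and compound 1 gives 68%. Within the data shown here, only these two numbers are available, and they cannot be told apart: the single measured step is a number 8 percentage points higher from compound 1 to compound 2 (within the scatter). That step puts phenyl in place of methyl on an oxygen on an aromatic ring.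

Compound 3 `COc1cc2c(cc1CC=C(C)C)C(=O)C[C@@H](c1ccc(Oc3ccc(Br)cc3)cc1)O2` changes compound 2 in one place: bromo in place of hydrogen on an aromatic carbon. This turns phenoxy into 4-bromophenoxy. Among the measured compounds shown here, no measured step involves bromo, so the step above is only a loose guide, and it stayed within the scatter. No change beyond the scatter is therefore expected in this assay. The expected size is a number 1 percentage points higher from compound 2 to compound 3 (within the scatter). Compound 3 is estimated at 77%, with an expected range from 63% to 90%.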

Compound 3, percent growth inhibition at one concentration: 76%
Compound 3: the middle estimate sits 1 percentage points above what was measured; measured number inside the range.
By their numbers in this assay, from the lowest: compounds 1, 2 and 3 (each within the scatter of the next).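

In this assay, putting bromo on this aromatic carbon gives no change at the digits printed from compound 2 to compound 3 (within the scatter) and swapping methyl on the oxygen for 4-bromophenyl gives a number 8 percentage points higher from compound 1 to compound 3 (within the scatter) so neither step can be told from the scatter. This adds something that compounds 1 and 2 could not show: the phenoxy group of compound 2 can carry a bromine atom at this place, para to a large group, without a readable shift in growth inhibition. Nothing available explains why the number holds steady.

Going by these compounds, whether an amine or a carboxylic acid at this same place would move the number beyond the scatter remains open. Each number also comes from a single concentration, so these compounds may or may not separate at lower concentrations.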